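Moving the chloro group: compound 3 from compound 1

This account rests on a few compounds, and the source may have more. Where it says the series, first, only, none or still open, it means among the compounds named here.

Measured so far:
compound 1 `Cc1nn(C)c2c1C(c1ccccc1)=NCC(=O)N2` gives 10 mg/kg
compound 2 `Cc1nn(C)c2c1C(c1ccccc1Cl)=NCC(=O)N2` gives 2.5 mg/kg

In a functional assay on the whole organism (strain Holtzman) with Rattus norvegicus as the target (a higher number here means that more compound is needed for the effect, a lower number that less compound is needed), compound 1 has the highest number of the two measured compounds, its nearest neighbour being compound 2, reached by a 4.0-fold lower number from compound 1 to compound 2 (0.60 log units; beyond the scatter). Compound 3 `Cc1nn(C)c2c1C(c1cccc(Cl)c1)=NCC(=O)N2` has not been measured yet. It differs from compound 1 by chloro in place of hydrogen on an aromatic carbon. Among the measured compounds shown here, the only step that bears on this change is the one from compound 1 to compound 2, which also adds a chloro on an aromatic carbon, though at a different place on the same ring; that step was a 4.0-fold lower number from compound 1 to compound 2 (0.60 log units; beyond the scatter), a modest fall. With no measurement of a chloro at this new place, the expectation is a smaller fall, perhaps none beyond the scatter, leaning toward a lower number because of a 4.0-fold lower number from compound 1 to compound 2 (0.60 log units; beyond the scatter). Compound 3 is therefore estimated at 6 mg/kg, within 2.5 mg/kg to 15 mg/kg, which is expected to mean a 1.7-fold lower number from compound 1 to compound 3 (0.22 log units; within the scatter).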

Compound 3, minimum effective dose: > 40 mg/kg
Compound 3 gave a limit, no number (the forecaster's own chance of this, stated with the estimate: 5%); middle value at least 6.6-fold (0.82 log units) from the limit.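

The value of compound 3 in this assay is a limit of the assay, not a number: the limit of > 40 mg/kg in this assay, at which 1 of the 3 values shown sits. Even so, the direction is clear, with an at least 4.0-fold higher number from compound 1 to compound 3 (0.60 log units; beyond the scatter), so a chloro meta to a large group takes the number up, whereas a chloro at a different place on the same ring took it down, with a 4.0-fold lower number from compound 1 to compound 2 (0.60 log units; beyond the scatter). Across compound 1, compound 2 and compound 3, the same exchange of hydrogen for chloro therefore moves the number in opposite directions, depending on where on the ring it is made.

From the compounds shown here alone, how far the true number of compound 3 lies past its limit remains open. Going by these compounds, it is also open whether a methoxy group or an amine at this same place would raise the number as the chloro does.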